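The source may hold more compounds than are shown below. What is called first, only, known or untested is meant among the compounds shown, and "the series" means these compounds.

Of the compounds shown here, two have so far been measured in an in vivo functional assay on the whole organism for inhibition of 3-hydroxy-3-methylglutaryl-coenzyme A reductase (Rattus norvegicus), at a dose of 0.2 mg/kg by the oral route; on this read-out higher numbers stand for a stronger effect at the one dose given and lower numbers for a weaker effect. Compound 1 `COc1ccc(-n2nc(C)c3c(-c4ccc(F)cc4)c(/C=C/[C@@H](O)C[C@@H](O)CC(=O)O)c(C(C)C)nc32)cc1` gives -27.5% in this assay. Compound 2 `CC(C)c1cc2nc(C3CC3)c(/C=C/[C@@H](O)C[C@@H](O)CC(=O)O)c(-c3ccc(F)cc3)n2n1` gives 21.8% in this assay. Of these two numbers, compound 2 stands highest, and its gap to compound 1 lies beyond the usual scatter of repeated measurements. Going by the values given here, no two measured compounds differ in only one place, so nothing here yet shows how a single small change moves this read-out.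

Compound 3 `Cc1cc2nc(C3CC3)c(/C=C/[C@@H](O)C[C@@H](O)CC(=O)O)c(-c3ccc(F)cc3)n2n1` has not yet been measured. It differs from compound 2 in one exchange: methyl in place of isopropyl on an aromatic carbon. Among the compounds with values here, the acid-bearing chain, the fluorine-bearing ring and the fused core are kept; only the one group goes from isopropyl to methyl. Within the data shown here, with no comparable step among the measured compounds, the main guide is the value of compound 2 in this assay, 21.8%, and a small exchange of this kind is expected to give a step of a number 7.8 percentage points lower from compound 2 to compound 3 (within the scatter), a modest fall that may well stay within the scatter. Compound 3 is therefore estimated at 14% in this assay, with a range from -12% to 40%.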

Compound 3, a percentage reported as inhibition, in the whole organism at one dose (the size of the read-out at that dose, not a potency): -27.1%
For compound 3 the middle estimate is 41.1 percentage points above the measured one; measured number below the stated range.
By their numbers in this assay, from the lowest: compounds 1 and 3 (each within the scatter of the next); then compound 2.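

In this assay, putting methyl in place of isopropyl on this aromatic carbon of the five-membered ring gives a number 48.9 percentage points lower from compound 2 to compound 3 (beyond the scatter), while the acid-bearing chain, the fluorine-bearing ring and the shared core stay the same. Going by these compounds alone, this is the first pair of compounds that differ in only one place, and it shows that this position is far from a bystander: a change from a group of 3 heavy atoms to a group of 1 is enough to separate a positive read-out from a negative one at this single dose. The data offer no measurement that would explain why the read-out moves so far with this small exchange.

With only isopropyl and methyl shown at this position, it remains open whether the effect follows group size in a steady way or whether ethyl, tert-butyl or a longer chain would match or exceed isopropyl. Going by these compounds, it is also open whether the same exchange would have a similar effect on a different core, and whether it would look the same at other doses.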